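Trifluoromethyl for Nitrooxy: Cytotoxicity Across Four Related Compounds

The source may hold more compounds than are shown below. What is called first, only, known or untested is meant among the compounds shown, and "the series" means these compounds.

The account begins with compound 1 `O=C1/C(=C/c2ccccc2F)CN(S(=O)(=O)c2ccc(O[N+](=O)[O-])cc2)C/C1=C\c1ccccc1F`, which in an ADME assay on L02 cells (Homo sapiens) for cytotoxicity, read by MTT assay, with a stated time of 24 h (on this read-out lower numbers stand for stronger inhibition and higher numbers for weaker inhibition), gives 15500 nM. Compound 2 `O=C1/C(=C/c2ccccc2F)CN(S(=O)(=O)c2ccc(C(F)(F)F)cc2)C/C1=C\c1ccccc1F` differs from compound 1 by one change, (trifluoromethyl in place of nitrooxy on an aromatic carbon), and in this assay compound 2 gives 16200 nM. The step is a 1.0-fold higher number from compound 1 to compound 2 (0.02 log units; within the scatter), so the two values lie within the scatter of each other.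

Compound 3 `O=C1/C(=C/c2ccc(F)cc2)CN(S(=O)(=O)c2ccc(O[N+](=O)[O-])cc2)C/C1=C\c1ccc(F)cc1` carries the same nitrooxy group as compound 1 on a different core; the difference between the two cores is not broken down here. In this assay compound 3 gives 16200 nM, a value that sits within the scatter of the value of compound 2 and of the value of compound 1, so none of the three measured compounds can be set apart from the others.

Compound 4 `O=C1/C(=C/c2ccc(F)cc2)CN(S(=O)(=O)c2ccc(C(F)(F)F)cc2)C/C1=C\c1ccc(F)cc1` has not yet been measured. It stands to compound 3 as compound 2 stands to compound 1: the change is trifluoromethyl in place of nitrooxy on an aromatic carbon, the same change in the same place. Because the step of a 1.0-fold higher number from compound 1 to compound 2 (0.02 log units; within the scatter) stayed within the scatter, the step from compound 3 to compound 4 is expected to be of the same size, namely a 1.0-fold higher number from compound 3 to compound 4 (0.01 log units; within the scatter). On that basis compound 4 is estimated to give 16500 nM in this assay, with the expected range running from 9000 nM to 30000 nM.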

Compound 4, half-maximal inhibitory concentration: 13500 nM
The estimate for compound 4 lay 1.2-fold (0.09 log units) above the measured number; measured number inside the range.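

In this assay, the same exchange of nitrooxy for trifluoromethyl on the second core gives a 1.2-fold lower number from compound 3 to compound 4 (0.08 log units; within the scatter), so on this core too the step cannot be told apart from repeated measurement. Set beside the step on the first core, the new step shows no difference that the data can resolve: the same change on two cores in this assay, a 1.0-fold higher number (0.02 log units; within the scatter) from compound 1 to compound 2 and a 1.2-fold lower number (0.08 log units; within the scatter) from compound 3 to compound 4, 1.3-fold (0.10 log units) apart, within the scatter of two such steps What this shows is that, on these two cores, the exchange left the cytotoxicity reading within the scatter both times, which is what one would see if the change carried over unaltered; it does not show that the change has no effect in general, since two steps that are each within the scatter offer no measurable shift to follow from one core to the other, and two cores say nothing about any third core or about any other assay.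

The compounds shown leave open how an amine, a carboxylic acid or a longer chain in that same place would read in this assay. They also leave open whether the exchange would stay this small on a core carrying chlorine or a methoxy group where these cores carry fluorine.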